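Replacing 2-Methoxyphenyl with 3-Cyanophenyl in Compound 2

The source may hold more compounds than are shown below. What is called first, only, known or untested is meant among the compounds shown, and "the series" means these compounds.

In a toxicity assay on MT4 cells (Homo sapiens) for cytotoxicity, read by MTT assay (on this read-out higher numbers stand for lower toxicity in this test and lower numbers for higher toxicity in this test), compound 2 (`COc1ccccc1-c1cc(C)c(Oc2cc(N)nc(Nc3ccc(C#N)cc3)n2)c(C)c1`) gives 21800 nM and sits within the scatter of compound 1 (`Cc1cc(-c2ccccc2F)cc(C)c1Oc1cc(N)nc(Nc2ccc(C#N)cc2)n1`), which gives 29300 nM on the same read-out. Compound 3 (`Cc1cc(-c2cccc(C#N)c2)cc(C)c1Oc1cc(N)nc(Nc2ccc(C#N)cc2)n1`) carries 3-cyanophenyl in place of 2-methoxyphenyl on an aromatic carbon. Among the measured compounds shown here, with a 1.3-fold lower number from compound 1 to compound 2 (0.13 log units; within the scatter) as the only measured step, a swap of methoxy in place of fluoro on an aromatic carbon, the estimated 1.1-fold lower number from compound 2 to compound 3 (0.04 log units; within the scatter) is expected to stay within the scatter, in no set direction. The estimate for compound 3 is 20000 nM and the expected range runs from 8000 nM up to 50000 nM on this read-out.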

Compound 3, half-maximal cytotoxic concentration: 20200 nM
The estimate for compound 3 lay 1.0-fold (0.00 log units) below the measured number; the range from low to high includes it.
By their numbers in this assay, from the lowest: compounds 3, 2 and 1 (each within the scatter of the next).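

In this assay the swap to 3-cyanophenyl gives a 1.1-fold lower number from compound 2 to compound 3 (0.03 log units; within the scatter) from 2-methoxyphenyl and a 1.5-fold lower number from compound 1 to compound 3 (0.16 log units; within the scatter) from 2-fluorophenyl. Compound 1 and compound 2 compared only 2-fluorophenyl with 2-methoxyphenyl, whereas compound 3 alters both the substituent and its place on the phenyl ring, and the numbers still stay within the scatter of each other. Nothing measured here bears on the reason for this result.

Going by these compounds, whether an amine or a carboxylic acid on this phenyl ring would also stay within the scatter remains open. So does the outcome of replacing the ring with a longer chain.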